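Changing the aryl group on an aromatic nitrogen

A few compounds are considered here, and "the series" means these few. Any claim that something is new, unique, unknown or untested is made for them only; others in the source may bear on it.

In a functional assay on HepG2 cells (Homo sapiens) for inhibition, read by MTT assay, with a stated time of 72 h (on this read-out lower numbers stand for stronger inhibition and higher numbers for weaker inhibition), compound 1 `Cc1cc2occ(-c3nc(-c4ccccc4)c(-c4ccccc4)n3-c3cccc([N+](=O)[O-])c3)c(=O)c2cc1Cl` gives 25000 nM and compound 2 `Cc1cc2occ(-c3nc(-c4ccccc4)c(-c4ccccc4)n3-c3ccc(Br)cc3)c(=O)c2cc1Cl` gives 6250 nM on the same read-out. Among the compounds with values here, compound 2 thus holds the lower of the two numbers so far. Within the data shown here, the one measured step is a 4.0-fold lower number from compound 1 to compound 2 (0.60 log units; beyond the scatter) and it exchanges 3-nitrophenyl for 4-bromophenyl on an aromatic nitrogen.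

Compound 3 `COc1cccc(-n2c(-c3coc4cc(C)c(Cl)cc4c3=O)nc(-c3ccccc3)c2-c2ccccc2)c1` keeps the shared core and changes that same place, with 3-methoxyphenyl in place of 4-bromophenyl on an aromatic nitrogen. The count of this change reads 3-methoxyphenyl in place of 4-bromophenyl on an aromatic nitrogen in full. Among the measured compounds shown here, no compound with 3-methoxyphenyl has been measured, and a single step sets no rule. The nearest guide is compound 1 with its 3-nitrophenyl group, which gives 25000 nM on the higher side of the pair. A modest rise is therefore expected, probably no larger than the measured step. The expected step is a 1.9-fold higher number from compound 2 to compound 3 (0.28 log units; within the scatter) in this assay as a rough estimate. For compound 3 the estimated value is 12000 nM with an expected range from 4000 nM to 30000 nM in this measurement.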

Compound 3, half-maximal inhibitory concentration: 6250 nM
The estimate for compound 3 lay 1.9-fold (0.28 log units) above the measured number; the range from low to high includes it.
By their numbers in this assay, from the lowest: compounds 2 and 3 (each within the scatter of the next); then compound 1.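

In this assay, putting 3-methoxyphenyl in place of 4-bromophenyl on the aromatic nitrogen gives no change at the digits printed from compound 2 to compound 3 (within the scatter), so these two different aryl groups cannot be told apart on this read-out. Within the data shown here, the new compound also gives the first comparison with the ring substituent's place held the same, as methoxy in place of nitro on an aromatic carbon gives a 4.0-fold lower number from compound 1 to compound 3 (0.60 log units; beyond the scatter); among the three compounds, only the 3-nitrophenyl group of compound 1 stands apart from the other two. No measurement is at hand that would explain either step, or the match between compound 2 and compound 3.

The 4-bromophenyl and 3-methoxyphenyl groups differ both in their substituent and in its place on the ring, so the compounds shown cannot separate these two changes, and their matching numbers need not mean that each change alone has no effect. On these data alone, it also remains open whether an amine or a carboxylic acid on this aryl group would give a number close to those of compound 2 and compound 3 or one closer to that of compound 1.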